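This account rests on a few compounds, and the source may have more. Where it says the series, first, only, none or still open, it means among the compounds named here.

In an ADME assay on BE(2)-C cells (Homo sapiens) for cytotoxicity, read by MTT assay, with a stated time of 20 h (a lower number here means that less compound is tolerated, a higher number that more compound is tolerated), compound 1 (`CN1CCN(C(=O)C2CCN(C(=O)c3cc4ccccc4n3Cc3ccc(Cl)cc3)CC2)CC1`) gives 75600 nM and compound 2 (`O=C(NCC1COc2cnccc21)C1CCN(C(=O)c2cc3ccccc3n2Cc2ccc(Cl)cc2)CC1`) gives 75800 nM on the same scale, two values within the scatter of each other. Compound 2 therefore stands level with compound 1, and neither can be ranked ahead of the other on these numbers. Compound 3 (`O=C(NCCn1ccnc1)C1CCN(C(=O)c2cc3ccccc3n2Cc2ccc(Cl)cc2)CC1`) differs from compound 2 by a single change (a group of 6 heavy atoms (4 carbon, 2 nitrogen; one five-membered aromatic ring with 2 hetero atoms) in place of a group of 9 heavy atoms (7 carbon, 1 nitrogen, 1 oxygen; one five-membered non-aromatic ring with 1 hetero atom, one six-membered aromatic ring with 1 hetero atom), on a saturated chain carbon bound to an amide-type nitrogen), with the (1H-imidazol-1-yl)methyl group entering on a saturated chain carbon bound to an amide-type nitrogen. Among the measured compounds shown here, only one measured step bears on this. The step of a 1.0-fold higher number from compound 1 to compound 2 (0.00 log units; within the scatter) stayed within the scatter, but it concerned a group on a carbonyl carbon, so it speaks only loosely to the place altered now. For the measured compounds named here, no measured compound carries the (1H-imidazol-1-yl)methyl group. On this slim evidence, no step beyond the scatter is expected in this assay for this change, and the estimated 1.1-fold lower number from compound 2 to compound 3 (0.03 log units; within the scatter) would remain inside it. Compound 3 is expected at 70000 nM with an estimated range from 38000 nM to 130000 nM in this measurement.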

Compound 3, half-maximal cytotoxic concentration: 99600 nM
The estimate for compound 3 lay 1.4-fold (0.15 log units) below the measured number, within the range that was stated.
By their numbers in this assay, from the lowest: compounds 1, 2 and 3 (each within the scatter of the next).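

In this assay, among the compounds shown here, the first measured change at this place, on a saturated chain carbon bound to an amide-type nitrogen, exchanges the two-ring group for (1H-imidazol-1-yl)methyl and gives a 1.3-fold higher number from compound 2 to compound 3 (0.12 log units; within the scatter), so a single five-membered aromatic ring serves here as well as the larger group did. Seen from the carbonyl carbon, (2-(1H-imidazol-1-yl)ethyl)amino in place of 4-methylpiperazin-1-yl gives a 1.3-fold higher number from compound 1 to compound 3 (0.12 log units; within the scatter), which means that three different groups at this end of the shared core now sit within the scatter of one another in this cytotoxicity read-out. Nothing measured on these compounds bears on why the read-out stays level across these changes.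

The compounds shown leave open whether any group at this place can produce a step beyond the scatter, for instance a primary amine or a carboxylic acid at the end of the chain, or a longer chain carrying the same imidazole ring. They also leave open whether the level read-out holds when the shared core itself is altered, since all three compounds carry it unchanged.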